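Hydroxylated aryl variants on a hydrazone-linked oxadiazole core

The source may hold more compounds than are shown below. What is called first, only, known or untested is meant among the compounds shown, and "the series" means these compounds.

Compound 1 `O=C(CSc1nnc(-c2ccncc2)o1)N/N=C/c1ccc(Cl)cc1` has the highest number in a functional assay on BGC-823 cells (Homo sapiens) for cytotoxicity, read by MTT assay, with a stated time of 48 h (a lower number here means a stronger inhibitor, a higher number a weaker inhibitor), of the two measured compounds, giving 20500 nM in this assay. Its closest measured relative, compound 2 `O=C(CSc1nnc(-c2ccncc2)o1)N/N=C/c1cc(Cl)ccc1O`, reaches 5470 nM in this assay, a 3.7-fold lower number from compound 1 to compound 2 (0.57 log units; beyond the scatter) change, where a hydroxyl-bearing aryl group replaces the plain chlorophenyl. Compound 3 `COc1cc(/C=N/NC(=O)CSc2nnc(-c3ccncc3)o2)ccc1O` carries the change (4-hydroxy-3-methoxyphenyl in place of 4-chlorophenyl on a carbon with a double bond to nitrogen). Among the compounds with values here, only the step from compound 1 to compound 2 bears on this move, since both exchanges put a hydroxyl on the aryl group attached to the carbon with a double bond to nitrogen, and that step was modest but beyond the scatter. A step of similar size and the same direction is therefore expected in this assay for compound 3, namely a 2.6-fold lower number from compound 1 to compound 3 (0.41 log units; beyond the scatter). Compound 3 is thus estimated at 8000 nM in this assay, within a range from 3000 nM to 22000 nM.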

Compound 3, half-maximal inhibitory concentration: 4320 nM
Beside the measured number, compound 3's estimate is 1.9-fold (0.27 log units) above it; the range from low to high includes it.
By their numbers in this assay, from the lowest: compounds 3 and 2 (each within the scatter of the next); then compound 1.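

In this assay, the exchange gives a 4.7-fold lower number from compound 1 to compound 3 (0.68 log units; beyond the scatter) with a second hydroxyl-bearing aryl group, so the lower number at this position does not rest on the 5-chloro-2-hydroxyphenyl group alone. The two hydroxyl-bearing groups are not separated, with a 1.3-fold lower number from compound 2 to compound 3 (0.10 log units; within the scatter) even though compound 3 carries no chlorine, so among these compounds chlorine is not needed for a number at this level. Nothing at hand accounts for the step from 4-chlorophenyl.

Both hydroxyl-bearing groups also carry a second substituent, which leaves open whether the hydroxyl alone would give such a step. Going by these compounds, how an amine or a carboxylic acid on this aryl group would read in this assay also remains open.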